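A few compounds are considered here, and "the series" means these few. Any claim that something is new, unique, unknown or untested is made for them only; others in the source may bear on it.

Measured in an ADME assay on MT4 cells (Homo sapiens) for cytotoxicity, read by MTT assay (a higher number here means that more compound is tolerated, a lower number that less compound is tolerated), so far:
compound 1 `CCOC(=O)/C(O)=C/C(=O)c1cn(Cc2cc(F)cc(F)c2)c2cccc(OC)c12`: 34700 nM
compound 2 `COc1cccc2c1c(C(=O)/C=C(\O)C(=O)O)cn2Cc1cc(F)cc(F)c1`: 29500 nM
compound 3 `COc1cccc2c1c(C(=O)/C=C(\O)C(=O)O)cn2Cc1ccc(F)cc1F`: 20800 nM

Compound 1 gives the highest number of the three, but this means little: a 1.2-fold lower number from compound 1 to compound 2 (0.07 log units; within the scatter) lies within the scatter, and the values of compound 1 and compound 3 are likewise too close to be told apart. Compound 4 `CCOC(=O)/C(O)=C/C(=O)c1cn(Cc2c(F)ccc(F)c2F)c2cccc(OC)c12` differs from compound 1 by 2,3,6-trifluorophenyl in place of 3,5-difluorophenyl on a saturated chain carbon bound to an aromatic nitrogen. Within the data shown here, the only measured step that bears on a change of the fluorine pattern on this benzyl group is a 1.4-fold lower number from compound 2 to compound 3 (0.15 log units; within the scatter), which stayed within the scatter. No step beyond the scatter is therefore expected in this assay; the expected step is a 1.2-fold lower number from compound 1 to compound 4 (0.06 log units; within the scatter). Compound 4 is estimated at 30000 nM, with a range from 12000 nM to 75000 nM.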

Compound 4, half-maximal cytotoxic concentration: 40500 nM
Compound 4: the middle estimate sits 1.4-fold (0.13 log units) below what was measured; the measured number falls inside the stated range.
By their numbers in this assay, from the lowest: compounds 3, 2, 1 and 4 (each within the scatter of the next).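

In this assay the change to 2,3,6-trifluorophenyl gives a 1.2-fold higher number from compound 1 to compound 4 (0.07 log units; within the scatter) so a third fluorine on this ring, on the ethyl ester, stays within the scatter. Tolerance at this position therefore extends beyond a shift of the two fluorines to an added one. No measurement here offers an explanation for this flat result. Still open, as far as these compounds go, is whether a benzyl group carrying an amine, or a longer chain between the phenyl ring and the aromatic nitrogen, would move the number beyond the scatter.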